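The source may hold more compounds than are shown below. What is called first, only, known or untested is meant among the compounds shown, and "the series" means these compounds.

Working notes on the amine end of the series. Compound 1 `O=S(=O)(NC[C@H](O)CN1CCCC1C1CC1)c1cccc2ccccc12` has been run twice in an assay on HEK293 cells for inhibition of sodium- and chloride-dependent glycine transporter 1 (Homo sapiens) (a lower number here means a stronger inhibitor, a higher number a weaker inhibitor), giving 501 nM; 1580 nM (2 entries) (the several entries of compound 1 in this assay, 501 nM; 1580 nM (2 entries)). Going by the values given here, compound 2 `CCCN(C[C@@H](O)CNS(=O)(=O)c1cccc2ccccc12)C(C)CC` shows 1260 nM in this assay, the only number given for it, beside one further entry that carries no number. The values of compound 1 and compound 2 lie close to each other, so neither can be set above the other.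

Compound 3 `CC[C@H]1CCCCN1C[C@@H](O)CNS(=O)(=O)c1cccc2ccccc12` is the next structure, awaiting measurement in this assay. It differs from compound 2 by 2-ethylpiperidin-1-yl in place of propyl(sec-butyl)amino on a saturated chain carbon, two bonds along the chain from an oxygen on a saturated carbon. Among the compounds with values here, no step between two measured neighbouring structures is available in this assay, so the size of this change cannot be read from a precedent. The expected step is a 1.4-fold lower number from compound 2 to compound 3 (0.15 log units; within the scatter), which stays within the scatter and points in no clear direction. Compound 3 is estimated at 900 nM, with a range from 250 nM to 3000 nM.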

Compound 3, half-maximal inhibitory concentration: 100 nM
Beside the measured number, compound 3's estimate is 9.0-fold (0.95 log units) above it; the measured number lies below the stated range.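

At the position on a saturated chain carbon, two bonds along the chain from an oxygen on a saturated carbon, the number in this assay does not follow heavy-atom count alone: 8 heavy atoms leave and 8 enter, yet 2-ethylpiperidin-1-yl in place of propyl(sec-butyl)amino gives a 13-fold lower number from compound 2 to compound 3 (1.10 log units; beyond the scatter). Going by these compounds alone, this is the first readable step, and it shows that a change at this position can move the number well beyond the scatter. Compound 3 also shows a lower number than both entries of compound 1: the several entries of compound 1 in this assay, 501 nM; 1580 nM (2 entries)

The compounds shown do not separate the contribution of the ring from that of the 2-ethyl group or its defined stereocentre. An unsubstituted piperidin-1-yl, a 2-methylpiperidin-1-yl or the opposite stereoisomer of 2-ethylpiperidin-1-yl would address this.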